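A few compounds are considered here, and "the series" means these few. Any claim that something is new, unique, unknown or untested is made for them only; others in the source may bear on it.

Measured compounds:
compound 1 `COc1ccc(OC)c(-c2cc(-c3ccccc3)nn2-c2ccc(S(=O)(=O)NC(C)=O)cc2)c1` gives 3740 nM in a functional assay on cells (Cancer cell lines, Homo sapiens) for cytotoxicity, read by sulforhodamine B assay, with a stated time of 48 h; on this read-out lower numbers stand for stronger inhibition of growth and higher numbers for weaker inhibition of growth;
compound 2 `NS(=O)(=O)c1ccc(-n2nc(-c3ccccc3)cc2-c2cc(O)ccc2O)cc1` gives 75700 nM in this assay.

Of the two measured compounds, compound 2 stands at the higher number, well apart from compound 1. The unmeasured compound 3 `CC(=O)NS(=O)(=O)c1ccc(-n2nc(-c3ccccc3)cc2-c2cc(O)ccc2O)cc1` keeps the core of compound 2 and differs from it by acetyl in place of hydrogen on a sulfonamide nitrogen. Compound 1 also carries this acetyl group, but it differs from compound 2 at more than one place, so the two values do not isolate the effect of the acetyl alone. Going by the values given here, with no single-change step available, only a cautious expectation can be given. The step from compound 2 to compound 3 is estimated as a moderate move toward lower numbers, a 2.5-fold lower number from compound 2 to compound 3 (0.40 log units; beyond the scatter), though a step within the scatter would not be surprising. Compound 3 is therefore expected at about 30000 nM, within 8000 nM to 120000 nM.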

Compound 3, concentration for 50% growth inhibition: 78600 nM
Compound 3: the middle estimate sits 2.6-fold (0.42 log units) below what was measured; low and high end bracket the measured number.
By their numbers in this assay, from the lowest: compound 1; then compounds 2 and 3 (each within the scatter of the next).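

With the 2,5-dihydroxyphenyl group in place, acetyl in place of hydrogen on a sulfonamide nitrogen gives a 1.0-fold higher number from compound 2 to compound 3 (0.02 log units; within the scatter) and so does not separate these two compounds in this assay. The large gap seen earlier can now be read at one place, with acetyl on both sides: 2,5-dihydroxyphenyl in place of 2,5-dimethoxyphenyl on an aromatic carbon gives a 21-fold higher number from compound 1 to compound 3 (1.32 log units; beyond the scatter) and accounts for a difference that the first two values could not isolate. Nothing measured here gives a reason for either step.

The compounds shown leave open whether the acetyl step would read the same with the 2,5-dimethoxyphenyl group present. They also leave open how a 2,5-diethoxyphenyl group or an amine on that aromatic carbon would stand.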